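Adding 4-hydroxybenzyl to compound 3

The compounds below may be only part of what the source reports. "The series", "measured", "known", "first", "only" and "open" are said of these compounds alone.

Compound 1 `COc1ccc2c(c1)cc(-c1cc(OC)c(OC)c(OC)c1)n2Cc1ccccc1`: > 30000 nM (a limit)
Compound 2 `COc1ccc2c(c1)cc(-c1cc(OC)c(OC)c(OC)c1)n2Cc1ccc(OCc2ccccc2)cc1`: > 30000 nM (a limit)
Compound 3 `COc1ccc2c(c1)cc(-c1cc(OC)c(OC)c(OC)c1)n2Cc1ccc(O)cc1`: > 30000 nM (a limit)

All three entries come from a functional assay on MCF7 cells (Homo sapiens) for cytotoxicity, read by MTT assay, with a stated time of 24 h; a higher number here means a weaker inhibitor, a lower number a stronger inhibitor. In this assay compound 3 gives > 30000 nM, which is a limit and not a number. It stands with the other two measured compounds: the limit of > 30000 nM in this assay, at which 3 of the 3 values shown sit.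

Compound 4 `COc1ccc2c(c1)c(Cc1ccc(O)cc1)c(-c1cc(OC)c(OC)c(OC)c1)n2Cc1ccc(O)cc1` is not yet measured. It differs from compound 3 by one change, 4-hydroxybenzyl in place of hydrogen on an aromatic carbon.

Within the data shown here, three measured steps bear on this only indirectly, since none of them changes that aromatic carbon. They are a step that the two limits leave unreadable from compound 1 to compound 2, a step that the two limits leave unreadable from compound 1 to compound 3 and a step that the two limits leave unreadable from compound 2 to compound 3. None of them yields a size or a direction to carry over. The nearest one in kind is a step that the two limits leave unreadable from compound 1 to compound 3, which adds a hydroxy group and still leaves no readable change.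

A modest move towards a stronger inhibitor remains possible, but a further limit is the more likely outcome. Compound 4 is expected at 25000 nM, with an estimated range of 6000 nM to 60000 nM. The expected change is an at least 1.2-fold lower number from compound 3 to compound 4 (0.07 log units; that floor lies within the scatter).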

Compound 4, half-maximal inhibitory concentration: > 30000 nM
Compound 4 ended at the assay's limit; the forecaster's own chance of this, stated with the estimate: 60%; at least 1.2-fold (0.07 log units) between middle value and limit.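

In this assay compound 4 gives > 30000 nM, a limit and not a number, and the step from compound 3, itself held at a limit, cannot be read. The series stands together: the limit of > 30000 nM in this assay, at which 4 of the 4 values shown sit. The compounds shown leave open what any of them would read as a number, and whether any of these changes alters the read-out.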